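Notes on the arm exchange from compound 3 to compound 4

The source may report more compounds than this note shows. Statements on the series, on what has been measured and on what is new or still open speak of the compounds shown alone.

Three compounds of one shared core have been run in an ADME assay on HEK293 cells (Homo sapiens) for antiproliferative activity, read by MTT assay, with a stated time of 24 h; a higher number here means a weaker inhibitor, a lower number a stronger inhibitor. Compound 1 `COc1ccc(-c2cc(/C=C/C(=O)c3cc(OC)c(OC)c(OC)c3)nc3cc(-c4ccccc4)nn23)cc1OC` gives 35000 nM; compound 2 `COc1cc(-c2cc(C(=O)/C=C/c3ccc(Cl)cc3)nc3cc(-c4ccccc4)nn23)cc(OC)c1OC` gives 53900 nM; compound 3 `COc1ccc(-c2cc(C(=O)/C=C/c3ccc(Cl)cc3)nc3cc(-c4ccccc4)nn23)cc1OC` gives 39100 nM. Compound 3 thus stands second highest of the three numbers, its gap to compound 1 and to compound 2 both inside the scatter. Among the compounds with values here, the only single-point step measured, a 1.4-fold lower number from compound 2 to compound 3 (0.14 log units; within the scatter), moved nothing beyond the scatter. Compound 4 `COc1ccc(C(=O)/C=C/c2cc(-c3ccc(OC)c(OC)c3)n3nc(-c4ccccc4)cc3n2)cc1` differs from compound 3 by 2-((4-methoxyphenyl)carbonyl)ethenyl in place of (2-(4-chlorophenyl)ethenyl)carbonyl on an aromatic carbon. Within the data shown here, no measured step bears directly on this exchange; the three numbers cluster tightly, and a 1.4-fold lower number from compound 2 to compound 3 (0.14 log units; within the scatter) gives no sign of a large move. A step of a 1.0-fold higher number from compound 3 to compound 4 (0.01 log units; within the scatter) is therefore expected, none beyond the scatter. Compound 4 is estimated at 40000 nM, with a range from 15000 nM to 110000 nM.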

Compound 4, half-maximal inhibitory concentration: 40000 nM
Compound 4: middle estimate and measured number agree at the digits printed, within the range that was stated.
By their numbers in this assay, from the lowest: compounds 1, 3, 4 and 2 (each within the scatter of the next).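

Working in one assay (this assay), replacing (2-(4-chlorophenyl)ethenyl)carbonyl with 2-((4-methoxyphenyl)carbonyl)ethenyl on this aromatic carbon stays within the scatter (a 1.0-fold higher number from compound 3 to compound 4 (0.01 log units; within the scatter)). On the carbonyl carbon of the arm, 4-methoxyphenyl in place of 3,4,5-trimethoxyphenyl also stays within the scatter (a 1.1-fold higher number from compound 1 to compound 4 (0.06 log units; within the scatter)). No measured evidence accounts for either result.

Open, going by these compounds, is whether an arm ending in an amine or a carboxylic acid instead of a substituted phenyl ring would move the number beyond the scatter at this position.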